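Growing the Ketone Branch from Compound 3 to Compound 4

The source may report more compounds than this note shows. Statements on the series, on what has been measured and on what is new or still open speak of the compounds shown alone.

Measured in an assay on HEK293 cells for positive allosteric modulation of metabotropic glutamate receptor 3 (Rattus norvegicus), read by thallium flux, with a stated time of 2.5 min; a higher number here means that more compound is needed for the effect, a lower number that less compound is needed:
- compound 1, `CCCC(=O)c1ccc(OCCCCOc2cccc(C(=O)O)c2C)c(C)c1O`: > 10000 nM
- compound 2, `Cc1c(OCCCCOc2ccc(C(=O)C(C)C)c(O)c2C)cccc1C(=O)O`: "not determined" (no result reported)
- compound 3, `CCC(=O)c1ccc(OCCCCOc2cccc(C(=O)O)c2C)c(C)c1O`: "not determined" (no result reported)
- compound 4, `Cc1c(OCCCCOc2ccc(C(=O)CC(C)(C)C)c(O)c2C)cccc1C(=O)O`: not yet measured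

All four compounds share one core, a linker joining two aromatic parts, and differ only in the ketone side chain on one part. For compound 1 the result in this assay is a limit, not a number. Within the data shown here, for compound 2 and compound 3 no result was recorded in this assay, so compound 3 stands with no value of its own, and the only reading in the set is the limit (the limit of > 10000 nM in this assay, at which 1 of the 3 values shown sits). Compound 4 differs from compound 3 by tert-butyl in place of methyl on a saturated chain carbon bound to a carbonyl carbon. Among the measured compounds shown here, without any measured step in this set, no direction can be read from the data; the one available reading suggests that weak activity is the expectation for this core. Compound 4 is therefore expected to give 8000 nM in this assay, in a range from 2000 nM to 30000 nM, with a real chance that only a limit is reported.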

Compound 4, half-maximal effective concentration: 300 nM
Compound 4: the middle estimate sits 27-fold (1.43 log units) above what was measured; measured number outside the range, below it.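

Among these compounds, compound 4 gives the first actual number in this set, 300 nM in this assay, which shows that the shared core can be active when the ketone side chain is changed. Tert-butyl in place of ethyl on a saturated chain carbon bound to a carbonyl carbon gives an at least 33-fold lower number from compound 1 to compound 4 (1.52 log units; beyond the scatter), so a change at this one place is enough to move a compound from an assay limit to a measured value. The reading for compound 1 is a limit, not a number: the limit of > 10000 nM in this assay, at which 1 of the 4 values shown sits.

Compound 2 and compound 3 have no result, so steps involving them cannot be read. On these data alone, it remains open whether tert-butyl itself is needed here, or whether a longer straight chain or a cyclohexyl ring at the same place could give a similar result.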